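The source may hold more compounds than are shown below. What is called first, only, known or untested is meant among the compounds shown, and "the series" means these compounds.

Among the measured compounds shown here, compound 3 `COc1c(C)cnc(C[S+]([O-])c2nnc(-c3cccc(F)c3)o2)c1C` holds the highest of the three numbers measured so far, though each of its steps to the others lies within the scatter. In a functional assay on HUVEC cells (Homo sapiens) for inhibition, read by ELISA (on this read-out higher numbers stand for weaker inhibition and lower numbers for stronger inhibition), compound 3 gives 12000 nM. Compound 2 `COc1c(C)cnc(C[S+]([O-])c2nnc(-c3ccc(F)cc3)o2)c1C` gives 11000 nM and compound 1 `CCc1nnc([S+]([O-])Cc2ncc(C)c(OC)c2C)o1` gives 10000 nM; the steps of a 1.1-fold higher number from compound 1 to compound 2 (0.04 log units; within the scatter), a 1.2-fold higher number from compound 1 to compound 3 (0.08 log units; within the scatter) and a 1.1-fold higher number from compound 2 to compound 3 (0.04 log units; within the scatter) are all within the scatter, so nothing separates the three. Compound 4 `COc1c(C)cnc(C[S+]([O-])c2nnc(-c3cccn3C)o2)c1C` differs from compound 3 in one place: 1-methyl-1H-pyrrol-2-yl in place of 3-fluorophenyl on an aromatic carbon. The measured steps that bear on this change are those among compounds 1, 2 and 3, where ethyl, 4-fluorophenyl and 3-fluorophenyl on an aromatic carbon gave numbers within the scatter of one another. For the measured compounds named here, none of the measured groups is a five-membered aromatic ring with a hetero atom, so the data do not cover the new group directly, but no measured step suggests a change beyond the scatter. The step of a 1.1-fold lower number from compound 3 to compound 4 (0.04 log units; within the scatter) is therefore expected to stay within the scatter. Compound 4 is expected to give 11000 nM, with a range from 5000 nM to 25000 nM.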

Compound 4, half-maximal inhibitory concentration: 4000 nM
Compound 4: the middle estimate sits 2.8-fold (0.44 log units) above what was measured; measured number outside the range, below it.
By their numbers in this assay, from the lowest: compound 4; then compounds 1, 2 and 3 (each within the scatter of the next).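

In this assay, this position on the five-membered aromatic ring with 2 nitrogen and 1 oxygen proves responsive to its substituent: 1-methyl-1H-pyrrol-2-yl brings a 3.0-fold lower number from compound 3 to compound 4 (0.48 log units; beyond the scatter) and also a 2.8-fold lower number from compound 2 to compound 4 (0.44 log units; beyond the scatter) and a 2.5-fold lower number from compound 1 to compound 4 (0.40 log units; beyond the scatter) in the steps from the other groups. Among the compounds shown here, these are the first steps that lie beyond the scatter, whereas ethyl, 4-fluorophenyl and 3-fluorophenyl gave numbers within the scatter of one another, and the modest size of all three steps sets the entering group apart from each of them. Nothing is available that explains this difference.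

The compounds shown leave open whether a furyl, a thienyl or a pyrrolyl without the methyl group would give a similar step. They also leave open whether a pyridyl, a six-membered aromatic ring holding a ring nitrogen, would do the same.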